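Pyridin-2-yl in place of 3-fluorophenyl: tolerance expected unchanged

A few compounds are considered here, and "the series" means these few. Any claim that something is new, unique, unknown or untested is made for them only; others in the source may bear on it.

Of the compounds shown here, two sharing one core have been tested in a toxicity assay on THP-1 cells (Homo sapiens) for inhibition; a higher number here means that more compound is tolerated, a lower number that less compound is tolerated. Compound 1, `CCCC(=O)Nc1ncc(-c2ccc(OC)cc2)n1C`, carries a propyl group on the carbonyl carbon of its amide. In this assay compound 1 gives > 100000 nM, which is a limit of the assay rather than a measured number. Compound 2, `COc1ccc(-c2cnc(NC(=O)c3cccc(F)c3)n2C)cc1`, carries a 3-fluorophenyl group on that same carbonyl carbon. In this assay compound 2 gives > 100000 nM, again a limit and not a number. Compound 2 therefore stands at the edge of what the assay can report, with no measured value beneath it.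

Compound 3, `COc1ccc(-c2cnc(NC(=O)c3ccccn3)n2C)cc1`, has not yet been measured. It differs from compound 2 by pyridin-2-yl in place of 3-fluorophenyl on a carbonyl carbon. Among the compounds with values here, the one recorded step, a step that the two limits leave unreadable from compound 1 to compound 2, concerns a change at the same carbonyl carbon, but its size cannot be read because of the limit of > 100000 nM in this assay, at which 2 of the 2 values shown sit. Within the data shown here, no measured step points to any change beyond the scatter. Compound 3 is therefore expected to sit at the same limit, so the expected step of a number no higher from compound 2 to compound 3 (the limit leaves the size open) is none beyond the scatter. Compound 3 is estimated at 100000 nM, within a range from 50000 nM to 200000 nM.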

Compound 3, half-maximal cytotoxic concentration: > 100000 nM
Compound 3 ended at the assay's limit (the forecaster's own chance of this, stated with the estimate: 85%); the middle value sits exactly at the limit.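

No step among compound 1, compound 2 and compound 3 can be read, because all three values are the same limit rather than measured numbers: the limit of > 100000 nM in this assay, at which 3 of the 3 values shown sit.

The compounds shown leave open how much of each compound is tolerated, and whether propyl, 3-fluorophenyl and pyridin-2-yl on the carbonyl carbon differ in this respect at all.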